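This account rests on a few compounds, and the source may have more. Where it says the series, first, only, none or still open, it means among the compounds named here.

Measured compounds:
compound 1 `Cc1ccc(C(=O)CCc2nnc(-c3ccccc3Cl)o2)cc1` gives 57.3% in a functional assay on the whole organism (strain Wistar) for inhibition, with Rattus norvegicus as the target, with stated times of 30 min and 3 h, at a dose of 20 mg/kg by the oral route; on this read-out lower numbers stand for less inhibition and higher numbers for more inhibition at the one dose given (going by the name of the read-out)
compound 2 `Cc1ccc(C(=O)CCc2nnc(-c3ccc(Cl)cc3)o2)cc1` gives 81.5% in this assay

Among the compounds with values here, compound 2 stands highest of the two numbers in this assay; its only neighbour is compound 1, and the step of a number 24.2 percentage points higher from compound 1 to compound 2 (beyond the scatter) lies beyond the scatter. The unmeasured compound 3 `Cc1ccc(C(=O)CCc2nnc(Cc3ccccc3)o2)cc1` is reached from compound 2 by the change (benzyl in place of 4-chlorophenyl on an aromatic carbon). Within the data shown here, the one measured step exchanged a 2-chlorophenyl for a 4-chlorophenyl and gave a number 24.2 percentage points higher from compound 1 to compound 2 (beyond the scatter); it does not exchange an aryl for a benzyl, so no measured step bears directly on the change at hand, and the only point of comparison is that the 4-chlorophenyl of compound 2 goes with the higher of the two numbers. Among the measured compounds shown here, removing that group is therefore expected to give a decrease of modest size, a number 21.5 percentage points lower from compound 2 to compound 3 (beyond the scatter), though with wide uncertainty, since the data hold no example of a benzyl on this carbon. Compound 3 is accordingly estimated at 60% in this assay, with a range from 38% to 80%.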

Compound 3, a percentage reported as inhibition, in the whole organism at one dose (the size of the read-out at that dose, not a potency): 51.9%
Compound 3: middle estimate off by 8.1 percentage points, on the high side; measured number inside the range.
By their numbers in this assay, from the lowest: compounds 3 and 1 (each within the scatter of the next); then compound 2.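

Within the data shown here, putting benzyl in place of 4-chlorophenyl on this aromatic carbon gives a number 29.6 percentage points lower from compound 2 to compound 3 (beyond the scatter) in this assay and is the first measured exchange of an aryl group for a benzyl at this position, showing that keeping one six-membered aromatic ring of carbon only, with no hydrogen-bond donors or acceptors, does not keep the higher number. Putting benzyl in place of 2-chlorophenyl gives a number 5.4 percentage points lower from compound 1 to compound 3 (within the scatter) and so separates these two groups by no measurable margin; of the three groups tried here, only the 4-chlorophenyl of compound 2 stands apart, with steps beyond the scatter to both compound 1 and compound 3. Nothing available explains why this one group stands apart.

The compounds shown leave open how a plain phenyl or a benzyl carrying a chlorine on its ring would compare at this position, and so whether the chlorine, the benzyl carbon or both go with the difference. They also leave open whether a longer chain such as phenethyl, or an amine on this carbon, would fall with compound 3 or reach the number of compound 2.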